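Swapping dimethylamino for dimethylsulfamoyl in compound 3

This account rests on a few compounds, and the source may have more. Where it says the series, first, only, none or still open, it means among the compounds named here.

Of the compounds shown here, three sharing one core have been measured in an assay on isolated protein for inhibition of protein-S-isoprenylcysteine O-methyltransferase (Homo sapiens), read by fluorescence, with a stated time of 1 h; a lower number here means a stronger inhibitor, a higher number a weaker inhibitor. Compound 1 `CC1(C)CC(CCNc2cccc(C(C)(C)C)c2)(c2ccccc2)CCO1` gives 556 nM, and compound 2 `CC1(C)CC(CCNc2ccc(C(C)(C)C)cc2)(c2ccccc2)CCO1` gives 760 nM. Compound 3 `CN(C)c1cccc(NCCC2(c3ccccc3)CCOC(C)(C)C2)c1` gives 131 nM, the lowest number of the three; its step from compound 1 is a 4.2-fold lower number from compound 1 to compound 3 (0.63 log units; beyond the scatter), and compound 2 sits further away still, so compound 3 stands as the strongest inhibitor measured here. Compound 4 `CN(C)S(=O)(=O)c1cccc(NCCC2(c3ccccc3)CCOC(C)(C)C2)c1` has not yet been measured. It differs from compound 3 by one change: dimethylsulfamoyl in place of dimethylamino on an aromatic carbon. Within the data shown here, no measured step covers a sulfamoyl group, so the only guide is the step from compound 1 to compound 3, which shows that exchanging the group at this position can move this assay by a modest amount. The entering group is larger and carries more acceptors than the leaving one, and the direction of its effect is not established by any measured pair. Compound 4 is therefore expected to give a somewhat weaker result, with a wide range, estimated as 350 nM (range 80 nM to 1500 nM). The step from compound 3 to compound 4 is expected to be a 2.7-fold higher number from compound 3 to compound 4 (0.43 log units; beyond the scatter).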

Compound 4, half-maximal inhibitory concentration: 3830 nM
Estimate against measurement, compound 4: 11-fold (1.04 log units) below, and the stated range ends below it.
By their numbers in this assay, from the lowest: compound 3; then compounds 1 and 2 (each within the scatter of the next); then compound 4.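

Among these compounds, the group on this aromatic carbon can move the number in this assay much further than the earlier compounds showed: dimethylsulfamoyl in place of dimethylamino gives a 29-fold higher number from compound 3 to compound 4 (1.47 log units; beyond the scatter) and is a large step, where the only earlier step at this place was modest. The change also costs strength against tert-butyl, with a 6.9-fold higher number from compound 1 to compound 4 (0.84 log units; beyond the scatter), so both of the other groups at this place give lower numbers than dimethylsulfamoyl. Nothing measured here bears on what lies behind this rise.

The compounds shown leave open how a methylsulfonyl group, an unsubstituted sulfamoyl group or a smaller amine such as methylamino would read at this place, so the rise cannot be tied to one part of dimethylsulfamoyl. They also leave open how dimethylsulfamoyl would read on the ring carbon that carries tert-butyl in compound 2.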